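The source may hold more compounds than are shown below. What is called first, only, known or untested is meant among the compounds shown, and "the series" means these compounds.

In a functional assay on DLD-1 cells (Homo sapiens) (on this read-out lower numbers stand for stronger inhibition and higher numbers for weaker inhibition), compound 2 `N#Cc1ccc(Cn2cncc2CN(C(=O)c2ccccc2)c2ccc(N3CCN(C(=O)c4ccc(Cl)s4)CC3)cc2)cc1` gives 3 nM, the lowest of the two numbers recorded there. Compound 1 `O=S(=O)(c1ccccc1)N(Cc1c[nH]cn1)c1ccc(N2CCN(C(=S)NC3CCCCC3)CC2)cc1` gives 1000 nM in this assay; the two values lie far apart, beyond the scatter, but the structures differ in many places at once, so nothing can be tied to any single change between them. Compound 3 `N#Cc1ccc(Cn2cncc2CN(C(=O)c2ccccc2F)c2ccc(N3CCN(C(=O)c4ccc(Cl)s4)CC3)cc2)cc1` has not yet been measured in this assay. It differs from compound 2 in one place only: fluoro in place of hydrogen on an aromatic carbon, sitting ortho to a large group, so that the benzoyl of compound 2 becomes (2-fluorophenyl)carbonyl. Among the measured compounds shown here, no pair of measured compounds shows this change, so there is no step to draw on. A single fluorine added to the benzoyl is a small alteration, and compound 3 is expected to stay close to compound 2. The step of no change at the digits printed from compound 2 to compound 3 (within the scatter) is estimated to fall within the usual scatter, in either direction. Compound 3 is therefore estimated at 3 nM, with a range of 1.2 nM to 8 nM.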

Compound 3, half-maximal inhibitory concentration: 20 nM
Beside the measured number, compound 3's estimate is 6.7-fold (0.82 log units) below it; the whole stated range lies below it.
By their numbers in this assay, from the lowest: compound 2; then compound 3; then compound 1.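

In this assay, placing fluoro on an aromatic carbon of the benzoyl, ortho to a large group, gives a 6.7-fold higher number from compound 2 to compound 3 (0.82 log units; beyond the scatter), which means weaker inhibition beyond the scatter. Among the compounds shown here, this is the first change that can be tied to one place, and it shows that this position of the benzoyl is not indifferent to substitution: the entry of fluoro, only 1 heavy atom in place of a hydrogen atom, is enough to move the read-out. The data hold no measurement that would account for this loss, so it stands as an observation alone.

With only this one step at the position, the compounds shown leave open whether the loss belongs to fluoro itself or would follow any group placed there, such as chloro, methyl or methoxy. They also leave open whether fluoro on another carbon of the same phenyl ring would move the number as well, and whether the same step would appear with the other parts of compound 2 changed.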